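The compounds below may be only part of what the source reports. "The series", "measured", "known", "first", "only" and "open" are said of these compounds alone.

Measured so far:
- compound 1, `COc1ccc(F)cc1CNCCCNc1ccnc2cc(Cc3cc(C)cc(C)c3)ccc12`: 4200 nM
- compound 2, `COc1cccc(CNCCCNc2ccnc3cc(Cc4ccccc4)ccc23)c1O`: 4200 nM
- compound 3, `COc1cccc(CNCCCNc2ccnc3cc(-c4ccccc4)ccc23)c1O`: 32000 nM

In a physicochemical assay for solubility, with a stated time of 18 h, at pH 7.4 (on this read-out higher numbers stand for higher solubility and lower numbers for lower solubility), compound 1 stands level with compound 2 at the digits printed, the two together the lowest of the three numbers, and compound 3 sits a 7.6-fold higher number from compound 2 to compound 3 (0.88 log units; beyond the scatter) above them. Compound 4, `COc1ccc(F)cc1CNCCCNc1ccnc2cc(-c3ccc(C(C)(C)C)cc3)ccc12`, differs from compound 1 as 4-(tert-butyl)phenyl in place of 3,5-dimethylbenzyl on an aromatic carbon. Among the compounds with values here, the one measured step that bears on this is the one from compound 2 to compound 3, which carries the same benzyl-to-phenyl change and gave a 7.6-fold higher number from compound 2 to compound 3 (0.88 log units; beyond the scatter). The present step adds a tert-butyl in place of the two methyls, for which no comparison exists, so the gain is expected to be smaller and less certain, about a 2.4-fold higher number from compound 1 to compound 4 (0.38 log units; beyond the scatter). Compound 4 is therefore estimated at 10000 nM, within 3000 nM to 40000 nM.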

Compound 4, solubility: 32000 nM
The estimate for compound 4 lay 3.2-fold (0.51 log units) below the measured number, within the range that was stated.
By their numbers in this assay, from the lowest: compounds 1 and 2 (each within the scatter of the next); then compounds 3 and 4 (each within the scatter of the next).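

In this assay, 4-(tert-butyl)phenyl in place of 3,5-dimethylbenzyl on this aromatic carbon gave a 7.6-fold higher number from compound 1 to compound 4 (0.88 log units; beyond the scatter), matching at the digits printed the earlier 7.6-fold higher number from compound 2 to compound 3 (0.88 log units; beyond the scatter). The rise therefore appears in two pairs with different substituted benzylamine parts, and here the entering group also carries a tert-butyl. No evidence given here accounts for this rise. The compounds shown leave open how much of the step belongs to the change from benzyl to phenyl and how much to the tert-butyl. They also leave open how an amine or a carboxylic acid on the entering ring would read.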